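Replacing a Sulfamoyl Chain with a Methylsulfanyl Chain

A few compounds are considered here, and "the series" means these few. Any claim that something is new, unique, unknown or untested is made for them only; others in the source may bear on it.

Of the compounds shown here, two have been measured in a functional assay on the whole organism with Rattus norvegicus as the target; a higher number here means that more compound is needed for the effect, a lower number that less compound is needed. Compound 1 `Nc1nc2ccc(C(F)(F)C(F)(F)F)cc2s1` gives 2.5 mg/kg. Compound 2 `N=c1sc2cc(OC(F)(F)F)ccc2n1CCS(N)(=O)=O` gives 6 mg/kg, the higher of the two numbers, and the gap to compound 1 lies beyond the usual scatter. Compound 3 `CSCCCn1c(=N)sc2cc(OC(F)(F)F)ccc21` is not yet measured. It differs from compound 2 by (methylsulfanyl)methyl in place of sulfamoyl on a saturated chain carbon, two bonds along the chain from an aromatic nitrogen. Among the measured compounds shown here, no pair of measured compounds shows what such a change does in this assay. For compound 3 only a small step is expected, a 1.2-fold lower number from compound 2 to compound 3 (0.08 log units; within the scatter), in no particular direction beyond the scatter. For compound 3 the estimated value is 5 mg/kg, most likely between 2 mg/kg and 15 mg/kg.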

Compound 3, dose for half-maximal effect: 4.2 mg/kg
Beside the measured number, compound 3's estimate is 1.2-fold (0.08 log units) above it; low and high end bracket the measured number.
By their numbers in this assay, from the lowest: compounds 1, 3 and 2 (each within the scatter of the next, the first and the last beyond it).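

In this assay, exchanging sulfamoyl for (methylsulfanyl)methyl on the saturated chain carbon gives a 1.4-fold lower number from compound 2 to compound 3 (0.15 log units; within the scatter) and so leaves the two chains indistinguishable. Among the compounds shown here, this is the first sign that the sulfamoyl group, with its hydrogen-bond donor, can be given up at this place without a step beyond the scatter. Still open, as far as these compounds go, is whether a carboxylic acid, an amine or a longer chain at this place would also stay within the scatter. From the compounds shown here alone, it is equally open whether a plain butyl chain, without the sulfur, would do so. No supporting data bear on this result.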